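A few compounds are considered here, and "the series" means these few. Any claim that something is new, unique, unknown or untested is made for them only; others in the source may bear on it.

Measured in a functional assay on MDA-MB-231 cells (Homo sapiens) for cytotoxicity, read by ELISA, with a stated time of 2 days; on this read-out higher numbers stand for weaker inhibition and lower numbers for stronger inhibition:
- compound 1 `Oc1ccc(-c2cc(-c3ccccc3)cc(-c3ccccc3)n2)cc1`: 1300 nM
- compound 2 `Oc1ccc(-c2cc(-c3ccccc3)cc(-c3ccsc3)n2)cc1`: 5700 nM
- compound 3 `Oc1ccc(-c2cc(-c3ccccc3)cc(-c3ccco3)n2)cc1`: 1400 nM

These three differ only in one ring on the shared core. Compound 3 cannot be told apart from its phenyl parent, as a 1.1-fold higher number from compound 1 to compound 3 (0.03 log units; within the scatter) shows, but it clearly outperforms its thiophene relative, as a 4.1-fold lower number from compound 2 to compound 3 (0.61 log units; beyond the scatter) shows.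

Compound 4 `Oc1ccc(-c2cc(-c3ccccc3)cc(-c3cccnc3)n2)cc1` has pyridin-3-yl in place of furan-2-yl on an aromatic carbon. Going by the values given here, no measured compound carries this group, so the evidence is indirect. Among the compounds with values here, two steps bear on it, both starting from phenyl at this spot. Furan-2-yl changed nothing beyond the scatter, with a 1.1-fold higher number from compound 1 to compound 3 (0.03 log units; within the scatter), whereas thiophen-3-yl cost a modest amount, with a 4.4-fold higher number from compound 1 to compound 2 (0.64 log units; beyond the scatter). Swapping this ring has therefore given either no real change or a modest rise in the number. The expected move is small and towards weaker inhibition, at a 1.4-fold higher number from compound 3 to compound 4 (0.15 log units; within the scatter), which would not stand clear of the scatter. For compound 4 the estimated value is 2000 nM, with an expected range of 800 nM to 5500 nM.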

Compound 4, half-maximal inhibitory concentration: 2200 nM
Compound 4: the middle estimate sits 1.1-fold (0.04 log units) below what was measured; measured number inside the range.
By their numbers in this assay, from the lowest: compounds 1, 3 and 4 (each within the scatter of the next); then compound 2.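

In this assay, a six-membered ring with a nitrogen at this spot stays level with both furan-2-yl (a 1.6-fold higher number from compound 3 to compound 4 (0.20 log units; within the scatter)) and phenyl (a 1.7-fold higher number from compound 1 to compound 4 (0.23 log units; within the scatter)), yet it remains clearly apart from thiophen-3-yl (a 2.6-fold lower number from compound 2 to compound 4 (0.41 log units; beyond the scatter)). Of the four rings shown, thiophen-3-yl alone therefore stands apart, while ring size and a hetero atom as such do not by themselves move the number beyond the scatter. No measurement here explains why thiophen-3-yl differs from the other three.

Still open, as far as these compounds go, is how this position responds to something other than an aromatic ring, such as an amine, a carboxylic acid or a longer chain. From the compounds shown here alone, it is equally open whether pyridin-4-yl would behave like pyridin-3-yl.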